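This account rests on a few compounds, and the source may have more. Where it says the series, first, only, none or still open, it means among the compounds named here.

Working notes on the series. In a functional assay on MV4-11 cells (Homo sapiens) for antiproliferative activity, read by luminescence and CellTiter-Glo, with a stated time of 72 h (a lower number here means a stronger inhibitor, a higher number a weaker inhibitor), compound 1 (`Cc1ccc(Cn2nc(Nc3ccc(F)cc3)c3ccc(-c4c(C)noc4C)cc32)cc1`) stands at "not determined" (no result reported) and compound 2 (`COc1ccc(Cn2nc(Nc3ccc(F)cc3OC)c3cc(-c4c(C)noc4C)ccc32)cc1`) at "not determined" (no result reported) and neither offers a number to work from. For the measured compounds named here, compound 3 (`CNc1cc(-c2ccc3cnn(Cc4ccc(F)cc4)c3c2)cn(C)c1=O`) gives 2390 nM as the only number, so it has no rank and serves as the single point of reference.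

Compound 4 (`CNc1cc(-c2ccc3cnn(Cc4ccc(OC)c(F)c4)c3c2)cn(C)c1=O`) has not yet been measured and differs from compound 3 in one place only. The change is 3-fluoro-4-methoxyphenyl in place of 4-fluorophenyl on a saturated chain carbon bound to an aromatic nitrogen and amounts to 3-fluoro-4-methoxyphenyl in place of 4-fluorophenyl on a saturated chain carbon bound to an aromatic nitrogen.

Going by the values given here, no pair of measured compounds shows what a change at this place does, so the series offers no precedent for either size or direction. The expectation in this assay is therefore a small step, most likely none beyond the usual scatter, with only a slight lean toward a lower number. The estimate rests on compound 3 at 2390 nM and on nothing else that has been measured. The expected change is a 1.3-fold lower number from compound 3 to compound 4 (0.12 log units; within the scatter) and it remains an estimate with a wide margin. Compound 4 is expected at 1800 nM with an estimated range of 600 nM to 5500 nM in this read-out.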

Compound 4, half-maximal inhibitory concentration: 4980 nM
Beside the measured number, compound 4's estimate is 2.8-fold (0.44 log units) below it; the range from low to high includes it.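

In this assay the series gains its first reading at this position: 3-fluoro-4-methoxyphenyl in place of 4-fluorophenyl on a saturated chain carbon bound to an aromatic nitrogen gives a 2.1-fold higher number from compound 3 to compound 4 (0.32 log units; beyond the scatter) and so marks a modest loss of antiproliferative activity. The position is therefore not indifferent to a change in this aryl group, and the larger group, which by count brings one hydrogen-bond acceptor, is the weaker of the two in this pair. The single step combines the added methoxy group with a different fluorine placement and cannot separate them, and no measurement shown here explains the rise in the number.

Open, going by these compounds, is whether the methoxy group or the fluorine placement accounts for the step, which a plain 4-methoxyphenyl or an unsubstituted phenyl at this place would help to settle, and what an amine or a carboxylic acid on the aryl group, or a longer chain in place of the single carbon, would do. On these data alone, compounds 1 and 2 carry no number, so it also remains open whether this step would hold on their core.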